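The compounds below may be only part of what the source reports. "The series", "measured", "known", "first", "only" and "open" are said of these compounds alone.

Working notes on the series. Within the data shown here, compound 1 (`C[C@]1(C(=O)O)CC[C@H](C(=O)N2CC[C@](c3ccc(C(F)(C(F)(F)F)C(F)(F)F)cc3)(S(=O)(=O)c3ccc(F)cc3)C2)CC1`) is the only member with a number so far: in an ADME assay on microsomes from liver (Mus musculus) for metabolic stability, with a stated time of 10 min (a higher number here means that more of the compound is left, a lower number that less of the compound is left), compound 1 gives 93% and serves as the sole measured reference. Going by these compounds, compound 2 (`O=C(O)[C@H]1CC[C@](F)(C(=O)N2CC[C@](c3ccc(C(F)(C(F)(F)F)C(F)(F)F)cc3)(S(=O)(=O)c3ccc(F)cc3)C2)CC1`) offers no such reference: in this assay compound 2 is recorded as "not determined" (no result reported) and has no single number, so its standing remains open.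

Compound 3 (`O=C(O)C12CCC(C(=O)N3CC[C@](c4ccc(C(F)(C(F)(F)F)C(F)(F)F)cc4)(S(=O)(=O)c4ccc(F)cc4)C3)(CC1)CC2`) keeps the shared core of compound 2 and differs in one place. Compared with compound 2, it carries a group of 11 heavy atoms (9 carbon, 2 oxygen; 2 six-membered non-aromatic rings of carbon only) in place of a group of 10 heavy atoms (7 carbon, 2 oxygen, 1 fluorine; one six-membered non-aromatic ring of carbon only), on a carbonyl carbon and loses the group named 4-carboxy-1-fluorocyclohexyl.

Among the measured compounds shown here, no measured step exists for this change, so the expectation rests on compound 1 at 93% and on the structural comparison alone. Relative to that reference, the expected step in this assay is none beyond the usual scatter, with only a slight lean towards less compound remaining. Compound 3 is expected to read 88% (estimated range 70% to 97%).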

Compound 3, percent of the compound remaining: 73%
Estimate against measurement, compound 3: 15 percentage points above; the measured number falls inside the stated range.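

This place, on a carbonyl carbon, does not tolerate every group equally: in this assay the group of 11 heavy atoms with 2 six-membered non-aromatic rings of carbon only, in place of the group of 10 heavy atoms with one such ring, gives a number 20 percentage points lower from compound 1 to compound 3 (beyond the scatter). With a single measured compound, the series could not show before that a change at this place can move the read-out beyond the usual scatter, and steps involving compound 2 cannot be read because it has no result. No supporting data bear on the origin of this step.

Going by these compounds, whether compound 2, with its 4-carboxy-1-fluorocyclohexyl group, would read closer to compound 1 or to compound 3 in this assay stays open. Also open, on these data alone, is how this place would respond if the carboxylic acid in these groups gave way to a primary amide or a hydroxymethyl group, and whether the lower read-out of compound 3 would persist with such a replacement.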